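A Methyl Added to the Benzyl Ring

A few compounds are considered here, and "the series" means these few. Any claim that something is new, unique, unknown or untested is made for them only; others in the source may bear on it.

Compound 1, `Cc1c(C(=O)c2ccccc2)cc(C(=O)NCc2cccc(I)c2)n1Cc1ccccc1`, gives 5000 nM in a functional assay on M14 cells (Homo sapiens) for antiproliferative activity, read by MTT assay, with a stated time of 48 h; a higher number here means a weaker inhibitor, a lower number a stronger inhibitor.
Compound 2, `Cc1c(C(=O)c2ccccc2)cc(C(=O)NCc2cccc(Cl)c2)n1Cc1ccccc1`, gives 7500 nM in this assay.

For the measured compounds named here, of these two numbers, compound 2 carries the higher one, and the only measured step, a 1.5-fold higher number from compound 1 to compound 2 (0.18 log units; within the scatter), lies within the scatter, so the two compounds cannot be told apart on these data. Compound 3, `Cc1ccc(Cn2c(C(=O)NCc3cccc(Cl)c3)cc(C(=O)c3ccccc3)c2C)cc1`, is made from compound 2 by a single change: methyl in place of hydrogen on an aromatic carbon. Going by the values given here, no measured step speaks to this change; the one step that exists swaps one halogen for another on a different ring and says nothing about adding a methyl to the benzyl group. Among the compounds with values here, with no step bearing on it and nothing to set a direction, no movement in this assay beyond the scatter is expected for compound 3. The expected value for compound 3 is 7500 nM, with a range from 3000 nM to 18000 nM. This estimate corresponds to an expected step of no change at the digits printed from compound 2 to compound 3 (within the scatter), essentially no change.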

Compound 3, half-maximal inhibitory concentration: 2500 nM
Beside the measured number, compound 3's estimate is 3.0-fold (0.48 log units) above it; measured number outside the range, below it.
By their numbers in this assay, from the lowest: compounds 3, 1 and 2 (each within the scatter of the next, the first and the last beyond it).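

Going from benzyl to 4-methylbenzyl gives the first step in this series that clears the scatter: in this assay there is a 3.0-fold lower number from compound 2 to compound 3 (0.48 log units; beyond the scatter), a modest move toward a stronger inhibitor, whereas the halogen swap on the other benzyl group, a 1.5-fold higher number from compound 1 to compound 2 (0.18 log units; within the scatter), could not be told from noise. This shows that the benzyl group is a place where a single added methyl, just one heavy atom, can shift the antiproliferative read-out on these cells, and that a small change here can count for more than exchanging chloro and iodo did at the other site. Nothing measured here explains the shift.

With only methyl shown at this position, it remains open whether a group such as ethyl, methoxy or an amine would take the number further down, leave it alone or reverse the gain. From the compounds shown here alone, it is also open whether the methyl would give a similar step when the iodo group of compound 1 replaces the chloro group of compound 2.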